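Amide to Urea on a Shared Benzothiazole-Free Core Description

This account rests on a few compounds, and the source may have more. Where it says the series, first, only, none or still open, it means among the compounds named here.

Two compounds have been measured so far:
compound 1, `CCCC(C)C(=O)Nc1ccc2nc(NC(=O)C3CCCCC3)sc2c1`, 0.14 ug/mL;
compound 2, `CCCCCCCC(=O)Nc1nc2ccc(NC(=O)c3c(Cl)cccc3Cl)cc2s1`, 0.18 ug/mL.

In a functional assay on WI-38 VA13 cells (Homo sapiens) for cytotoxicity (on this read-out higher numbers stand for an effect only at larger amounts of compound and lower numbers for an effect already at smaller amounts), compound 2 gives the highest of the two numbers, with compound 1 the nearest at a slightly lower number, a gap that lies within the usual scatter. The two values therefore show no real difference between compound 1 and compound 2.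

Compound 3, `CCCCCCNC(=O)Nc1nc2ccc(NC(=O)c3c(Cl)cccc3Cl)cc2s1`, has not yet been measured. It differs from compound 2 in one place: hexylamino in place of heptyl on a carbonyl carbon. Within the data shown here, nothing measured so far speaks to this kind of exchange, so no direction can be read from the data, and the step from compound 2 to compound 3 is expected to stay within the scatter, a 1.4-fold higher number from compound 2 to compound 3 (0.14 log units; within the scatter). Compound 3 is estimated at 0.25 ug/mL in this assay, with a range of 0.08 ug/mL to 0.8 ug/mL.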

Compound 3, half-maximal effective concentration: 0.29 ug/mL
For compound 3 the middle estimate is 1.2-fold (0.06 log units) below the measured one, within the range that was stated.
By their numbers in this assay, from the lowest: compounds 1, 2 and 3 (each within the scatter of the next, the first and the last beyond it).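

In this assay, among these compounds, hexylamino in place of heptyl on a carbonyl carbon gives a 1.6-fold higher number from compound 2 to compound 3 (0.21 log units; within the scatter) and so is the first step that can be read at this position. It shows that turning heptylcarbonyl into hexylcarbamoyl, which adds a nitrogen and a hydrogen-bond donor to the chain, brings no change here that can be told apart from the scatter. No measurement is available that could explain this result.

The compounds shown leave open whether a shorter chain such as butylamino, a ring such as cyclohexylamino, or a chain ending in a carboxylic acid would stay equally close to compound 2 at this carbonyl carbon. Also open, going by these compounds, is how hexyloxy, with an oxygen where hexylamino has its nitrogen, would read in this assay on the same core.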